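From Methoxy to Hydrogen on the Shared Core

The source may hold more compounds than are shown below. What is called first, only, known or untested is meant among the compounds shown, and "the series" means these compounds.

Of the compounds shown here, three built on one shared core have been measured in a functional assay, read by spectrophotometry, with a stated time of 15 min, tested at 80 ug/mL; on this read-out lower numbers stand for a weaker effect and higher numbers for a stronger effect at the one concentration tested. Compound 1 `Fc1ccc(-c2csc(N/N=C/c3ccc(Cl)cc3Cl)n2)cc1` gives 94%, compound 2 `Cc1ccc(-c2csc(N/N=C/c3cccs3)n2)cc1` gives 88.4%, and compound 3 `COc1ccc(-c2csc(N/N=C/c3ccc(Cl)cc3Cl)n2)cc1` gives 84.2%. On these numbers compound 3 carries the lowest figure of the three, yet both of its gaps lie within the scatter: the nearest is compound 2 and the furthest is compound 1, so no ordering among them can be drawn. Going by the values given here, the only single-point step measured so far is a number 9.8 percentage points lower from compound 1 to compound 3 (within the scatter).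

Compound 4 `Clc1ccc(/C=N/Nc2nc(-c3ccccc3)cs2)c(Cl)c1` differs from compound 3 in one place: hydrogen in place of methoxy on an aromatic carbon. Among the compounds with values here, no measured pair shows a substituent on that carbon giving way to hydrogen, so the closest guide is the methoxy-for-fluoro exchange at the same position, which stayed within the scatter. The step in this assay from compound 3 to compound 4 is therefore expected to be small, a number 0.8 percentage points higher from compound 3 to compound 4 (within the scatter), with no clear direction. Compound 4 is estimated to give 85%, with a likely range from 72% to 95%.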

Compound 4, a percentage reported as inhibition, at one concentration (the size of the read-out at that concentration, not a potency): 83.1%
Compound 4: the middle estimate sits 1.9 percentage points above what was measured; measured number inside the range.
By their numbers in this assay, from the lowest: compounds 4, 3, 2 and 1 (each within the scatter of the next, the first and the last beyond it).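

In this assay, hydrogen on this aromatic carbon, para to a large group, is now set directly against two substituents, and the two exchanges do not read alike. Replacing methoxy with hydrogen gives a number 1.1 percentage points lower from compound 3 to compound 4 (within the scatter), so the 4-methoxyphenyl and phenyl forms cannot be told apart on this read-out, and the methoxy group shows no measurable contribution at this position. Going by these compounds alone, replacing fluoro with hydrogen, however, gives a number 10.9 percentage points lower from compound 1 to compound 4 (beyond the scatter), the first step at this position to pass beyond the scatter, though only modestly, and no account of why can be offered, as no independent evidence bears on this result.

The compounds shown leave open whether this modest step reflects something particular to fluoro or merely the spread of values among three closely spaced compounds, and each was read at only one concentration, which gives no potency. They also leave open how an amine, a carboxylic acid or a longer chain on this same carbon would read against hydrogen, and whether the step from fluoro to hydrogen would hold on a core carrying a different group at its other end.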